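A few compounds are considered here, and "the series" means these few. Any claim that something is new, unique, unknown or untested is made for them only; others in the source may bear on it.

Cytotoxicity is the only read-out here, measured in an ADME assay on GES1 cells (Homo sapiens) for cytotoxicity, read by MTT assay, with a stated time of 24 h; on this read-out higher numbers stand for lower toxicity in this test and lower numbers for higher toxicity in this test. Compound 1 `O=c1[nH]cc(S(=O)(=O)Nc2ccccc2-c2cn(-c3cccc(Cl)c3)nn2)c(=O)[nH]1` sits at the edge of the scale: in this assay compound 1 gives > 100000 nM, which is a limit of the assay and not a number. Compound 2 `Cc1ccccc1-n1cc(-c2ccc(NS(=O)(=O)c3c[nH]c(=O)[nH]c3=O)cc2)nn1` shares the core of compound 1; in this assay compound 2 is reported only as "not toxic" (no number reported), with no number attached. Compound 2 therefore stands nowhere on the numerical scale, and the only fixed point is the limit of > 100000 nM in this assay, at which 1 of the 2 values shown sits. Compound 3 `O=c1[nH]cc(S(=O)(=O)Nc2ccc(-c3cn(-c4cccc(F)c4)nn3)cc2)c(=O)[nH]1` differs from compound 2 by 3-fluorophenyl in place of 2-methylphenyl on an aromatic nitrogen. Within the data shown here, no measured step between two compounds exists in this set, so nothing shows how such a swap moves the read-out, and no shift beyond the scatter can be foreseen. Compound 3 is expected to come out near 150000 nM, within a range of 60000 nM to 400000 nM, most likely reported again as a limit.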

Compound 3, half-maximal cytotoxic concentration: "not toxic" (no number reported)
Compound 3: no number reported; there is nothing to compare the estimate with.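

Compound 2 and compound 3 are both reported in this assay only as not toxic, with no number attached, and no step can be read between them. From the compounds shown here alone, whether 3-fluorophenyl in place of 2-methylphenyl moves this read-out at all stays open.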